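A few compounds are considered here, and "the series" means these few. Any claim that something is new, unique, unknown or untested is made for them only; others in the source may bear on it.

Compound 1 `COc1cc(C(=O)c2sc(-c3ccc(Br)cc3)cc2N)cc(OC)c1OC`: 86 nM
Compound 2 `COc1cc(C(=O)c2sc(-c3ccc(F)cc3)cc2N)cc(OC)c1OC`: 15 nM
Compound 3 `COc1cccc(-c2cc(N)c(C(=O)c3cc(OC)c(OC)c(OC)c3)s2)c1`: 16 nM
Compound 4 `CCOc1ccc(-c2cc(N)c(C(=O)c3cc(OC)c(OC)c(OC)c3)s2)cc1`: not yet measured

In a functional assay on CCRF-CEM cells (Homo sapiens) for antiproliferative activity (on this read-out lower numbers stand for stronger inhibition and higher numbers for weaker inhibition), compound 3 gives 16 nM. Its nearest neighbour is close, with a 1.1-fold higher number from compound 2 to compound 3 (0.03 log units; within the scatter), which lies within the scatter. The furthest is well apart, with a 5.4-fold lower number from compound 1 to compound 3 (0.73 log units; beyond the scatter), which lies beyond the scatter.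

Compound 4 carries 4-ethoxyphenyl in place of 3-methoxyphenyl (4-ethoxyphenyl in place of 3-methoxyphenyl on an aromatic carbon), on the aromatic carbon next to the ring sulfur. Going by the values given here, no measured step makes this exact exchange, so the evidence is indirect. The two compounds with a group in the same 4-position of the phenyl differ clearly, with a 5.7-fold lower number from compound 1 to compound 2 (0.76 log units; beyond the scatter), a modest step. On these data alone, a change at this place can therefore matter, but its direction for ethoxy is unknown. A small move towards a higher number seems most likely, probably not beyond the scatter. The expected step is a 1.6-fold higher number from compound 3 to compound 4 (0.19 log units; within the scatter). For compound 4 the estimated value is 25 nM, with an expected range from 7 nM to 90 nM.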

Compound 4, half-maximal inhibitory concentration: 270 nM
Compound 4: the middle estimate sits 11-fold (1.03 log units) below what was measured, outside the stated range (above it).
By their numbers in this assay, from the lowest: compounds 2 and 3 (each within the scatter of the next); then compound 1; then compound 4.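

In this assay, going by these compounds alone, the aromatic carbon next to the ring sulfur proves far less forgiving than the earlier compounds showed, with a 17-fold higher number from compound 3 to compound 4 (1.23 log units; beyond the scatter) for this exchange of one alkoxyphenyl group for another. Ethoxy also stands apart from both halogens, with an 18-fold higher number from compound 2 to compound 4 (1.26 log units; beyond the scatter) against fluoro and a 3.1-fold higher number from compound 1 to compound 4 (0.50 log units; beyond the scatter) against bromo, so the spread at this place is wider than bromo and fluoro alone revealed. Nothing available explains why this exchange weakens activity so strongly.

Compound 4 differs from compound 3 in both the alkoxy chain and its place on the phenyl ring, so the compounds shown leave open which of the two accounts for the step. Direct comparisons with 4-methoxyphenyl and 3-ethoxyphenyl would separate these two changes.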